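Adding a second chloro to compound 3

The source may report more compounds than this note shows. Statements on the series, on what has been measured and on what is new or still open speak of the compounds shown alone.

In an ADME assay on L929 cells (Mus musculus) for cytotoxicity, read by resazurin assay, with a stated time of 96 h (on this read-out higher numbers stand for lower toxicity in this test and lower numbers for higher toxicity in this test), compound 1 `NC(=S)N/N=C(\COc1ccccc1)c1ccc(Br)cc1` gives 54900 nM and compound 2 `NC(=S)N/N=C(\COc1ccccc1Cl)c1ccc(Br)cc1` gives 25100 nM on the same read-out. Compound 3 `NC(=S)N/N=C(\COc1cccc(Cl)c1)c1ccc(Br)cc1` stands at a limit of < 50200 nM rather than at a number. Compound 4 `NC(=S)N/N=C(\COc1cccc(Cl)c1Cl)c1ccc(Br)cc1` differs from compound 3 by a chloro in place of hydrogen on an aromatic carbon, ortho to a chloro group (in counts: chloro in place of hydrogen on an aromatic carbon). The same kind of swap gave a 2.2-fold lower number from compound 1 to compound 2 (0.34 log units; beyond the scatter) as a modest step beyond the scatter, while an at least 1.0-fold lower number from compound 1 to compound 3 (0.03 log units; that floor lies within the scatter) is only a floor within the scatter. The step expected in this assay is therefore modest and towards lower numbers, so the estimated move is a step that the limit leaves unreadable from compound 3 to compound 4 and not much larger. Compound 4 is expected near 23000 nM with 10000 nM to 50000 nM as the estimated range.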

Compound 4, half-maximal cytotoxic concentration: 23100 nM
The estimate for compound 4 lay 1.0-fold (0.00 log units) below the measured number; measured number inside the range.
By their numbers in this assay, from the lowest: compounds 4 and 2 (each within the scatter of the next); then compound 1.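

Among these compounds, a second chloro, placed ortho to a chloro group, gives a 1.1-fold lower number from compound 2 to compound 4 (0.04 log units; within the scatter) in this assay, so on this evidence it adds nothing readable to the single chloro of compound 2. Compound 3 holds only a limit, < 50200 nM, and the steps to and from compound 3 cannot be read. The same change on the two cores therefore cannot be compared closely: the same change on two cores in this assay, an at least 1.0-fold lower number (0.03 log units; that floor lies within the scatter) from compound 1 to compound 3 and a 1.1-fold lower number (0.04 log units; within the scatter) from compound 2 to compound 4; the limit leaves it open whether they differ

Still open, as far as these compounds go, is whether an amine or a methyl group at this place, instead of chloro, would move the number in this assay beyond the scatter.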